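Swapping Hydroxy for Dimethylamino in an Antiproliferative Pair

The source may hold more compounds than are shown below. What is called first, only, known or untested is meant among the compounds shown, and "the series" means these compounds.

In a functional assay on HeLa cells (Homo sapiens) for antiproliferative activity, read by MTT assay, with a stated time of 48 h (on this read-out lower numbers stand for stronger inhibition and higher numbers for weaker inhibition), compound 1 `COc1ccc(C(=O)c2ccc(OC)c3c2OC(C)(C)C=C3)c(NC(=O)CBr)c1` gives 2140 nM while compound 2 `COc1ccc(C(=O)c2ccc(OC)c3c2C=CC(C)(C)O3)c(NC(=O)CO)c1` gives 310 nM as its reading. Compound 2 therefore holds the lower of the two numbers, and its gap to compound 1 lies beyond the usual scatter. The two compounds differ in more than one place, so that gap cannot be tied to any single change.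

Compound 3 `COc1ccc(C(=O)c2ccc(OC)c3c2C=CC(C)(C)O3)c(NC(=O)CN(C)C)c1` keeps the core of compound 2 and alters one group, with dimethylamino in place of hydroxy on a saturated chain carbon bound to a carbonyl carbon. For the measured compounds named here, no measured pair shows this exchange, so the expectation rests on little. Going by the values given here, compound 2 with 310 nM has the lower of only two numbers, and a moderate move toward weaker inhibition is therefore expected, although a result within the scatter would not be surprising. The expected size of the move is a 1.4-fold higher number from compound 2 to compound 3 (0.13 log units; within the scatter) by this estimate. Compound 3 is estimated in this assay at 420 nM (130 nM to 1400 nM).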

Compound 3, half-maximal inhibitory concentration: 3620 nM
Compound 3: middle estimate off by 8.6-fold (0.94 log units), on the low side; the whole stated range lies below it.
By their numbers in this assay, from the lowest: compound 2; then compounds 1 and 3 (each within the scatter of the next).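

In this assay, for the compounds shown here, the exchange of hydroxy for dimethylamino on a saturated chain carbon bound to a carbonyl carbon comes with a 12-fold higher number from compound 2 to compound 3 (1.07 log units; beyond the scatter) and gives the first reading of a single change, showing that the result at this place depends strongly on the group it carries. The exchange removes the 1 hydrogen-bond donor of hydroxy, leaves 1 hydrogen-bond acceptor on each side and puts 3 heavy atoms where 1 stood, so the donor count and the group size change together in this one pair. No measurement offered here accounts for the size of the step.

On these data alone, what remains open is whether methoxy or a primary amine on the same carbon would read close to compound 2 or close to compound 3, which would begin to separate the loss of the donor from the larger group. A longer chain carrying hydroxy is also untested in the compounds shown, as is the same exchange on the core of compound 1.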